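The source may hold more compounds than are shown below. What is called first, only, known or untested is meant among the compounds shown, and "the series" means these compounds.

Measured in a functional assay on MKN-45 cells (Homo sapiens) for antiproliferative activity, tested at 1 uM (on this read-out higher numbers stand for more inhibition at the one concentration tested (going by the name of the read-out) and lower numbers for less inhibition), so far:
- compound 1, `COc1ccc(CO/N=C/c2c(C)nn(C)c2Oc2ccc(Cl)cc2)cc1`: 28.1%
- compound 2, `Cc1c(CO/N=C/c2c(-c3ccccc3)nn(-c3ccccc3)c2Oc2ccc(Cl)cc2)cccc1-c1ccccc1`: -15%

Compound 1 stands highest of the two numbers; compound 2 lies lower by a gap well beyond the scatter. For the measured compounds named here, no pair of measured compounds differs in one place, so no single step is known for this series.

Compound 3, `Cc1ccc(CO/N=C/c2c(C)nn(C)c2Oc2ccc(Cl)cc2)cc1`, differs from compound 1 in one place: methyl in place of methoxy on an aromatic carbon. Going by the values given here, no measured step speaks to this change, so the expected step in this assay is small, either way, and not beyond the scatter. For compound 3 the estimate is 24%, between 8% and 40%, an expected step of a number 4.1 percentage points lower from compound 1 to compound 3 (within the scatter).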

Compound 3, a percentage reported as inhibition, at one concentration (the size of the read-out at that concentration, not a potency): 30.4%
Estimate against measurement, compound 3: 6.4 percentage points below, within the range that was stated.
By their numbers in this assay, from the lowest: compound 2; then compounds 1 and 3 (each within the scatter of the next).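

In this assay, for the compounds shown here, methyl in place of methoxy on the aromatic carbon para to a large group gives a number 2.3 percentage points higher from compound 1 to compound 3 (within the scatter), the first single-place step. At this position, the two groups cannot be told apart on this read-out, even though methoxy carries a hydrogen-bond acceptor and methyl does not. No supporting data bear on this result.

Open, as far as these compounds go, is whether an amine, a carboxylic acid or a longer chain such as butoxy at this position would shift the number beyond the scatter. The compounds shown also do not separate the changes that distinguish compound 2 from compound 1.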